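Amide and urea variants on a shared alkyne-thiazole core

The compounds below may be only part of what the source reports. "The series", "measured", "known", "first", "only" and "open" are said of these compounds alone.

Working notes on a small set measured in an assay on HEK293 cells for negative allosteric modulation of metabotropic glutamate receptor 5 (Homo sapiens), read by FLIPR, with a stated time of 1 h; a higher number here means a weaker inhibitor, a lower number a stronger inhibitor. The shared core carries a phenylethynyl arm and a saturated ring bearing a nitrogen, and only the group on that nitrogen differs. Compound 1 `CCCCN1CCc2nc(C#Cc3ccccc3)sc2C1` carries a butyl chain there. In this assay compound 1 reports > 10000 nM, which is a limit of the assay rather than a number. Compound 2 `CC1CCC(C(=O)N2CCc3nc(C#Cc4ccccc4)sc3C2)CC1` carries a 4-methylcyclohexyl carbonyl on the same nitrogen. In this assay compound 2 reports > 10000 nM, again a limit and not a number. Compound 2 therefore stands at the limit of > 10000 nM in this assay, at which 2 of the 2 values shown sit, with no numeric value to place it within the set. Compound 3 `O=C(N1CCCC1)N1CCc2nc(C#Cc3ccccc3)sc2C1` is the next variant, and it differs from compound 2 by pyrrolidin-1-yl in place of 4-methylcyclohexyl on a carbonyl carbon. Among the compounds with values here, no measured pair in the set isolates this change, so no direction can be taken from the data. Compound 3 is expected to stay at the limit, with a step from compound 2 of about a step that the limit leaves unreadable from compound 2 to compound 3, which would be no more than the scatter. The estimate for compound 3 in this assay is 15000 nM, spanning 5000 nM to 50000 nM.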

Compound 3, half-maximal inhibitory concentration: > 10000 nM
Compound 3: no number, only a limit (the forecaster's own chance of this, stated with the estimate: 80%); the middle value does not contradict the limit.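

Within the data shown here, compound 3 gives > 10000 nM, a limit and not a number, so no step from compound 1 or compound 2 to compound 3 can be read. The compounds shown leave open how far the group on the nitrogen of the shared core, including pyrrolidin-1-yl in place of 4-methylcyclohexyl on a carbonyl carbon, affects inhibition.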